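Pyridin-3-yl replaces 2-hydroxycyclohexyl at the alkyne end

The source may hold more compounds than are shown below. What is called first, only, known or untested is meant among the compounds shown, and "the series" means these compounds.

Going by the values given here, compound 2 `CONc1nc(C#CC2CCCCC2O)nc2c1ncn2[C@@H]1O[C@H](CO)[C@@H](O)[C@H]1O` gives 1.7 nM in an assay on CHO cells for displacement of a labelled ligand from adenosine receptor A3 (Homo sapiens) (a lower number here means a stronger inhibitor, a higher number a weaker inhibitor), and stands lowest of the two numbers so far; its nearest neighbour, compound 1 `CONc1nc(C#CCCCC#N)nc2c1ncn2[C@@H]1O[C@H](CO)[C@@H](O)[C@H]1O`, gives 4.1 nM. Among the compounds with values here, the only measured step, a 2.4-fold lower number from compound 1 to compound 2 (0.38 log units; beyond the scatter), came from 2-hydroxycyclohexyl in place of 3-cyanopropyl on a triple-bonded carbon. Compound 3 `CONc1nc(C#Cc2cccnc2)nc2c1ncn2[C@@H]1O[C@H](CO)[C@@H](O)[C@H]1O` keeps the shared core of compound 2 and differs only in pyridin-3-yl in place of 2-hydroxycyclohexyl on a triple-bonded carbon. Within the data shown here, no measured step covers an aromatic group at this position, so the step from compound 1 to compound 2 is the sole guide, and it shows that changes at this end of the molecule move the number only modestly. A shift of at most similar size is expected here, with no firm direction, so the estimate is set near compound 2. Compound 3 is expected at 3 nM, with a range from 1 nM to 10 nM. For compound 3 the expected step is a 1.8-fold higher number from compound 2 to compound 3 (0.25 log units; within the scatter).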

Compound 3, inhibition constant: 7.9 nM
Estimate against measurement, compound 3: 2.6-fold (0.42 log units) below; low and high end bracket the measured number.
By their numbers in this assay, from the lowest: compound 2; then compounds 1 and 3 (each within the scatter of the next).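

In this assay, pyridin-3-yl on a triple-bonded carbon gives up the low number seen with 2-hydroxycyclohexyl, with a 4.6-fold higher number from compound 2 to compound 3 (0.67 log units; beyond the scatter), so an aromatic ring at the alkyne end does not hold that result. Against 3-cyanopropyl there is a 1.9-fold higher number from compound 1 to compound 3 (0.28 log units; within the scatter), so these two groups cannot be told apart here, and among the three groups only 2-hydroxycyclohexyl stands apart, with its steps to both others beyond the scatter. No measured data connect this difference to any property of the groups.

The compounds shown do not separate the part played by the hydroxyl of 2-hydroxycyclohexyl from that of its ring, which a plain cyclohexyl or phenyl would address. Also open, on these data alone, is how an amine or a carboxylic acid on a longer chain would read in this assay.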